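Methylpyridyl variant of a Substance-P receptor antagonist

A few compounds are considered here, and "the series" means these few. Any claim that something is new, unique, unknown or untested is made for them only; others in the source may bear on it.

Compound 1 `C[C@@H](O[C@H]1CN2C(=O)C=C(c3ccc(NS(C)(=O)=O)cc3)CC2[C@@H]1c1ccc(F)cc1)c1cc(C(F)(F)F)cc(C(F)(F)F)c1`: 1 nM
Compound 2 `C[C@@H](O[C@H]1CN2C(=O)C=C(c3ccc(CO)cc3)CC2[C@@H]1c1ccc(F)cc1)c1cc(C(F)(F)F)cc(C(F)(F)F)c1`: 0.39 nM
Compound 3 `C[C@@H](O[C@H]1CN2C(=O)C=C(c3ccncc3)CC2[C@@H]1c1ccc(F)cc1)c1cc(C(F)(F)F)cc(C(F)(F)F)c1`: 0.14 nM

In an assay on CHO cells for displacement of a labelled ligand from Substance-P receptor (Homo sapiens) (on this read-out lower numbers stand for stronger inhibition and higher numbers for weaker inhibition), compound 3 gives 0.14 nM and so stands lowest of the three measured numbers. Its two neighbours reach it by replacing a substituted phenyl with a pyridine: a 7.1-fold lower number from compound 1 to compound 3 (0.85 log units; beyond the scatter) and a 2.8-fold lower number from compound 2 to compound 3 (0.44 log units; beyond the scatter), both beyond the scatter, while the change between the two phenyl compounds is smaller, a 2.6-fold lower number from compound 1 to compound 2 (0.41 log units; beyond the scatter).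

Compound 4 `Cc1cc(C2=CC(=O)N3C[C@H](O[C@H](C)c4cc(C(F)(F)F)cc(C(F)(F)F)c4)[C@@H](c4ccc(F)cc4)C3C2)ccn1` keeps the core of compound 3 and differs by a single small change: methyl in place of hydrogen on an aromatic carbon. For the measured compounds named here, none of the measured steps alters a substituent on the pyridine itself, so no measured pair bears directly on this change; the only guidance is that compound 3 sits at the low end of the series. Because compound 3 gives 0.14 nM, the expectation for compound 4 is a number close to it, with a step of a 1.4-fold higher number from compound 3 to compound 4 (0.15 log units; within the scatter), likely within the scatter. Compound 4 is therefore estimated at 0.2 nM in this assay, within a range of 0.07 nM to 0.6 nM.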

Compound 4, half-maximal inhibitory concentration: 0.51 nM
Estimate against measurement, compound 4: 2.6-fold (0.41 log units) below; low and high end bracket the measured number.
By their numbers in this assay, from the lowest: compound 3; then compounds 2, 4 and 1 (each within the scatter of the next, the first and the last beyond it).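

In this assay, the pyridine ring proves sensitive at the carbon next to the ring nitrogen: going from pyridin-4-yl to 2-methylpyridin-4-yl gives a 3.6-fold higher number from compound 3 to compound 4 (0.56 log units; beyond the scatter), the first measured change made on the pyridine itself. With this one methyl, the separation that compound 3 shows from both phenyl compounds is gone, as a 1.3-fold higher number from compound 2 to compound 4 (0.12 log units; within the scatter) and a 2.0-fold lower number from compound 1 to compound 4 (0.29 log units; within the scatter) both lie within the scatter. No measurement shown here accounts for the size of the methyl step.

The compounds shown leave open whether an amino group, a methoxy group or a chlorine atom on this same carbon would give a number close to that of compound 3 or that of compound 4. They also leave open how a methyl group would read on another carbon of the pyridine ring.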